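Swapping morpholine for piperidine on the carbonyl

The compounds below may be only part of what the source reports. "The series", "measured", "known", "first", "only" and "open" are said of these compounds alone.

Measured in a functional assay (aorta) with Rattus norvegicus as the target; on this read-out higher numbers stand for an effect only at larger amounts of compound and lower numbers for an effect already at smaller amounts:
- Compound 1 `COc1ccc(-c2nc(CN)sc2-c2ccc(OC)cc2)cc1`: 7.7 uM
- Compound 2 `COc1ccc(-c2nc(C(=O)N=C(N)N)sc2-c2ccc(OC)cc2)cc1`: > 100 uM (a limit)
- Compound 3 `COc1ccc(-c2nc(C(=O)N3CCOCC3)sc2-c2ccc(OC)cc2)cc1`: < 100 uM (a limit)

Compound 3 has no exact number, and its < 100 uM is a limit. Compound 4 `COc1ccc(-c2nc(C(=O)N3CCCCC3)sc2-c2ccc(OC)cc2)cc1` keeps the shared core and the carbonyl and changes only the ring on it, with piperidin-1-yl in place of morpholin-4-yl on a carbonyl carbon.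

Among the measured compounds shown here, no measured step makes this exact change. The two steps that reach the morpholin-4-yl compound, a step that the limit leaves unreadable from compound 1 to compound 3 and a number no higher from compound 2 to compound 3 (the limit leaves the size open), give no readable size. For the measured compounds named here, the only readable step, an at least 12-fold higher number from compound 1 to compound 2 (1.11 log units; beyond the scatter), involves different groups, so it sets no size for this swap. It does show that this assay can move a long way when the group on the core changes. With no size to carry over, no firm direction can be expected, and a wide range is the honest choice.

The expected step is a step that the limit leaves unreadable from compound 3 to compound 4. Compound 4 is estimated at 40 uM, with an expected range from 8 uM to 150 uM.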

Compound 4, concentration for half-maximal effect: 11 uM
Compound 4: the middle estimate sits 3.6-fold (0.56 log units) above what was measured, within the range that was stated.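

In this assay, a ring on the carbonyl no longer rules out an effect at low micromolar amounts: a 1.4-fold higher number from compound 1 to compound 4 (0.15 log units; within the scatter), so (piperidin-1-yl)carbonyl and aminomethyl on an aromatic carbon cannot be told apart here. What sits on the carbonyl carbon also clearly matters, since piperidin-1-yl and the nitrogen-rich open group of compound 2 on that same carbon give an at least 9.0-fold lower number from compound 2 to compound 4 (0.95 log units; beyond the scatter). Compound 2 has only a limit, > 100 uM, so that step gives a minimum size and not an exact one.

On these data alone, the swap of morpholin-4-yl for piperidin-1-yl cannot be read, and it stays unknown whether replacing the ring oxygen with carbon changes anything, because compound 3 has no exact number: the limit of < 100 uM in this assay, at which 1 of the 4 values shown sits. How a piperazin-1-yl ring or an open diethylamino group would read on this carbonyl carbon remains open, as does a carboxylic acid on the aromatic carbon that carries the carbonyl in compound 4.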